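From a Dienyl Ester to a Shorter Unsaturated Ester

The compounds below may be only part of what the source reports. "The series", "measured", "known", "first", "only" and "open" are said of these compounds alone.

Measured in an ADME assay on HepG2 2.2.15 cells (Homo sapiens) for cytotoxicity; on this read-out higher numbers stand for lower toxicity in this test and lower numbers for higher toxicity in this test:
Compound 1 `COCC(=O)OCCc1c(-c2ccccc2Cl)c2cc(Cl)ccc2[nH]c1=O`: 74000 nM
Compound 2 `C/C=C/C=C/C(=O)OCCc1c(-c2ccccc2Cl)c2cc(Cl)ccc2[nH]c1=O`: 440000 nM

Compound 2 stands highest of the two measured compounds. Compound 3 `C/C=C(\C)C(=O)OCCc1c(-c2ccccc2Cl)c2cc(Cl)ccc2[nH]c1=O` differs from it by one change: 1-methylprop-1-en-1-yl in place of penta-1,3-dien-1-yl on a carbonyl carbon. Within the data shown here, only one measured step bears on this: a 5.9-fold higher number from compound 1 to compound 2 (0.77 log units; beyond the scatter), a modest one at the same place. The entering group is all carbon, as the leaving group is, unlike the methoxymethyl of compound 1, so only part of that step is expected to return. The estimated change is small and toward a lower number: a 1.8-fold lower number from compound 2 to compound 3 (0.25 log units; within the scatter). For compound 3 the estimated value is 250000 nM, with an expected range of 100000 nM to 520000 nM.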

Compound 3, half-maximal cytotoxic concentration: 350000 nM
The estimate for compound 3 lay 1.4-fold (0.15 log units) below the measured number, and the stated range covers the measured number.
By their numbers in this assay, from the lowest: compound 1; then compounds 3 and 2 (each within the scatter of the next).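

In this assay, 1-methylprop-1-en-1-yl on the carbonyl carbon reads the same as penta-1,3-dien-1-yl within the scatter (a 1.3-fold lower number from compound 2 to compound 3 (0.10 log units; within the scatter)). Against methoxymethyl at the same place, this second all-carbon group also stands apart (a 4.7-fold higher number from compound 1 to compound 3 (0.67 log units; beyond the scatter)), so losing one double bond and one carbon from the chain leaves the number at the level of compound 2. No evidence given here accounts for these numbers. As far as these compounds go, whether a saturated butyl chain or an amine at this place would hold that level remains open.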